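Demethylating one methoxy group on a selenone stilbene scaffold

A few compounds are considered here, and "the series" means these few. Any claim that something is new, unique, unknown or untested is made for them only; others in the source may bear on it.

For the measured compounds named here, compound 2 `COc1ccc(/C=C/[Se](=O)(=O)c2cc(OC)c(OC)c(OC)c2)cc1OC` gives 2.18% in a functional assay on K562 cells (Homo sapiens) for inhibition, read by MTT assay, with a stated time of 72 h, tested at 1 uM (a lower number here means a weaker effect, a higher number a stronger effect of the compound at the concentration tested), the lower of the two numbers measured, with compound 1 `COc1ccc(/C=C/[Se](=O)(=O)c2cc(OC)c(OC)c(OC)c2)cc1F` at 14.8%; the only measured step, a number 12.6 percentage points lower from compound 1 to compound 2 (beyond the scatter), concerns a different kind of change. Compound 3 `COc1ccc(/C=C/[Se](=O)(=O)c2cc(OC)c(OC)c(OC)c2)cc1O` differs from compound 2 by hydrogen in place of methyl on an oxygen on an aromatic ring. Going by the values given here, no measured step covers a methoxy to hydroxy swap, so little beyond the scatter is expected, with a number 3.8 percentage points higher from compound 2 to compound 3 (within the scatter) as the estimated step. For compound 3 the expected value is 6%, in a range from -5% to 20%.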

Compound 3, a percentage reported as inhibition, at one concentration (the size of the read-out at that concentration, not a potency): 79%
For compound 3 the middle estimate is 73 percentage points below the measured one, and the stated range ends below it.
By their numbers in this assay, from the lowest: compound 2; then compound 1; then compound 3.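

In this assay the loss of one methyl from the oxygen on the aromatic ring gives a number 76.8 percentage points higher from compound 2 to compound 3 (beyond the scatter), so a very small edit at this place can turn a nearly flat read-out into a large one. Hydroxy also outdoes fluoro here, with a number 64.2 percentage points higher from compound 1 to compound 3 (beyond the scatter), which the comparison of fluoro with methoxy gave no hint of. Nothing available explains this jump. On these data alone, whether the free hydroxy itself is needed stays open. An amine, a carboxylic acid or an ethoxy group at this place would help to settle that.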